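Swapping the Heteroaryl Arm on a Thienopyrimidine Scaffold

The source may hold more compounds than are shown below. What is called first, only, known or untested is meant among the compounds shown, and "the series" means these compounds.

Two compounds in this set share a core carrying an amino group and a benzyl arm, differing only in the aromatic ring attached on an aromatic carbon of the six-membered ring with two nitrogen atoms. Compound 1 `Cc1ccc(-c2nc(N)c3cc(Cc4ccccc4)sc3n2)o1` bears a 5-methylfuran-2-yl ring, and in a functional assay on CHO-K1 cells for antagonist activity at adenosine receptor A1 (Homo sapiens), read by a beta-galactosidase reporter and cAMP accumulation, with stated times of 15 min and 6 h (on this read-out higher numbers stand for weaker inhibition and lower numbers for stronger inhibition), compound 1 gives 298 nM. Compound 2 `Cc1nc(-c2nc(N)c3cc(Cc4ccccc4)sc3n2)cs1` bears a 2-methyl-1,3-thiazol-4-yl ring instead, and in this assay compound 2 gives 263 nM. The step of a 1.1-fold lower number from compound 1 to compound 2 (0.05 log units; within the scatter) is within the scatter, so compound 2 gives the lower of the two numbers without being distinguishable from compound 1.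

Compound 3 `Nc1nc(-c2cccnc2)nc2sc(Cc3ccccc3)cc12` carries the change (pyridin-3-yl in place of 2-methyl-1,3-thiazol-4-yl on an aromatic carbon). Going by the values given here, the only measured step that bears on this change, a 1.1-fold lower number from compound 1 to compound 2 (0.05 log units; within the scatter), shows that exchanging one five-membered heteroaryl ring for another at this position left the number essentially unchanged. Moving to a six-membered pyridin-3-yl ring is a somewhat larger change, with no direct precedent here, so the expectation is a step of modest size at most. Compound 3 is therefore expected to give 350 nM, with a range from 120 nM to 1000 nM, which corresponds to an expected step of a 1.3-fold higher number from compound 2 to compound 3 (0.12 log units; within the scatter).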

Compound 3, inhibition constant: 1420 nM
Estimate against measurement, compound 3: 4.1-fold (0.61 log units) below; measured number outside the range, above it.
By their numbers in this assay, from the lowest: compounds 2 and 1 (each within the scatter of the next); then compound 3.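

Exchanging one five-membered ring for the other left the number within the scatter, but the six-membered pyridin-3-yl ring gives clearly weaker inhibition in this assay against either of them (a 5.4-fold higher number from compound 2 to compound 3 (0.73 log units; beyond the scatter); a 4.8-fold higher number from compound 1 to compound 3 (0.68 log units; beyond the scatter)). So the aromatic carbon between two ring nitrogen atoms does not accept every aromatic ring equally, even when the entering and leaving groups, pyridin-3-yl and 2-methyl-1,3-thiazol-4-yl, have the same number of heavy atoms. Nothing available explains why the number rises at this position.

The change to compound 3 alters several things at once: the ring size, the number of hetero atoms and the presence of a methyl group, and these three compounds cannot separate them. A 6-methylpyridin-3-yl ring would test whether the methyl group matters on a six-membered ring, while a phenyl ring or a furan-2-yl ring without its methyl group would help show whether the ring size or the ring nitrogen is tied to the change.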